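Moving from 4-chlorophenyl to 3-bromophenyl

The compounds below may be only part of what the source reports. "The series", "measured", "known", "first", "only" and "open" are said of these compounds alone.

In a functional assay on HCT-116 cells (Homo sapiens) for antiproliferative activity, read by MTT assay, with a stated time of 72 h (on this read-out higher numbers stand for weaker inhibition and lower numbers for stronger inhibition), compound 1 (`O=C(CCc1cccc2c1B(O)OC2)Nc1ccccc1`) gives 350 nM, while compound 2 (`O=C(CCc1cccc2c1B(O)OC2)Nc1ccc(Cl)cc1`) gives 12000 nM. Compound 2 therefore holds the higher of the two numbers and is the weaker inhibitor of this pair.

Compound 3 (`O=C(CCc1cccc2c1B(O)OC2)Nc1cccc(Br)c1`) keeps the shared core, with 3-bromophenyl in place of 4-chlorophenyl on an amide-type nitrogen.

Among the compounds with values here, only one measured step bears on this change: a 34-fold higher number from compound 1 to compound 2 (1.54 log units; beyond the scatter). That large step, beyond the scatter, comes from chloro in place of hydrogen on an aromatic carbon. Within the data shown here, it is a single comparison and says nothing directly about 3-bromophenyl, which has no measured precedent. Compound 3 still carries a halogen, so a full return to the value of compound 1 is not assumed. Compound 2 sits high enough, however, that a partial return seems more likely than no change.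

A moderate move toward a lower number is expected, with an estimated 6.0-fold lower number from compound 2 to compound 3 (0.78 log units; beyond the scatter). The estimate for compound 3 is 2000 nM, with an expected range of 450 nM to 10000 nM.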

Compound 3, half-maximal inhibitory concentration: 1400 nM
The estimate for compound 3 lay 1.4-fold (0.15 log units) above the measured number, and the stated range covers the measured number.
By their numbers in this assay, from the lowest: compound 1; then compound 3; then compound 2.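

In this assay, replacing 4-chlorophenyl with 3-bromophenyl on the amide-type nitrogen gives an 8.6-fold lower number from compound 2 to compound 3 (0.93 log units; beyond the scatter), so this position does not treat these two halogen-bearing phenyl groups alike, and the high number of compound 2 does not extend to every halogen-bearing group here. The added bromo group still goes with a 4.0-fold higher number from compound 1 to compound 3 (0.60 log units; beyond the scatter), so among the three compounds both halogen-bearing members stand above compound 1, with compound 3 in the middle and no exception to that order. Within the data shown here, the data offered here contain no independent measurement that accounts for these differences, and the series so far describes the size of the changes only.

The step from compound 2 to compound 3 alters both the halogen and its place on the ring, leaving open which of the two changes carries the shift in the number. Also open, on these data alone, is how this position responds to groups other than a halogen, such as a methoxy group or an amine on the phenyl ring, and whether any such group can match or go below the number of compound 1.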